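The source may hold more compounds than are shown below. What is called first, only, known or untested is meant among the compounds shown, and "the series" means these compounds.

In a functional assay on HT-29 cells (Homo sapiens) for inhibition, read by CCK-8 assay, with a stated time of 24 h (a higher number here means a weaker inhibitor, a lower number a stronger inhibitor), the measured compounds stand as follows.

- compound 1 (`Cc1cccc(-n2cc(-c3ccc(/C=C4\C(=O)Nc5ccccc54)cc3)nn2)c1`) gives 3940 nM
- compound 2 (`O=C1Nc2ccccc2/C1=C/c1ccc(-c2cn(-c3ccccc3Cl)nn2)cc1`) gives > 20000 nM as a limit, not a number
- compound 3 (`N#Cc1ccc(-n2cc(-c3ccc(C=C4C(=O)Nc5ccccc54)cc3)nn2)cc1`) gives 15800 nM

Compound 2 has no number of its own and stands at the limit of > 20000 nM in this assay, at which 1 of the 3 values shown sits, on this scale. Compound 4 (`O=C1Nc2ccccc2/C1=C/c1ccc(-c2cn(-c3ccc(Cl)c(C(F)(F)F)c3)nn2)cc1`) keeps the core of compound 2 but carries 4-chloro-3-(trifluoromethyl)phenyl in place of 2-chlorophenyl on an aromatic nitrogen.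

Going by the values given here, one measured step touches this place. Bringing in 2-chlorophenyl in place of 3-methylphenyl gave an at least 5.0-fold higher number from compound 1 to compound 2 (0.70 log units; beyond the scatter) and that step is the closest guide, since compound 4 gives the same group up again. Without 2-chlorophenyl, compound 1 reads 3940 nM and compound 3 reads 15800 nM in this assay as real numbers, though these two lie some way apart. A move toward a lower number is therefore expected, likely smaller than the full return to compound 1, and compound 4 may yet remain at the limit. The step expected in this assay is an at least 2.5-fold lower number from compound 2 to compound 4 (0.39 log units; beyond the scatter) and it runs toward a stronger inhibitor. Compound 4 is expected at 8000 nM with an estimated range from 2500 nM to 20000 nM in this assay as its measurement.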

Compound 4, half-maximal inhibitory concentration: 9670 nM
Compound 4: middle estimate off by 1.2-fold (0.08 log units), on the low side, and the stated range covers the measured number.
By their numbers in this assay, from the lowest: compound 1; then compounds 4 and 3 (each within the scatter of the next). At a limit, above all of these: compound 2.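

In this assay, a chlorine on the phenyl ring at this position does not by itself hold a compound at the limit: 4-chloro-3-(trifluoromethyl)phenyl in place of 2-chlorophenyl gives an at least 2.0-fold lower number from compound 2 to compound 4 (0.31 log units; beyond the scatter), so a ring with more heavy atoms still gives a real reading on the aromatic nitrogen. Going by these compounds alone, that reading does not reach the level of the 3-methylphenyl group, and the change from that group gives a 2.5-fold higher number from compound 1 to compound 4 (0.39 log units; beyond the scatter), so the extra chlorine and trifluoromethyl groups bring no gain over the single methyl group in this pair. The size of the first step stays open-ended, since compound 2 has no number of its own and stands at a limit: the limit of > 20000 nM in this assay, at which 1 of the 4 values shown sits.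

Compound 4 differs from compound 2 in both the place of the chlorine and the presence of the trifluoromethyl group, so the compounds shown cannot say which of the two accounts for the recovered reading. They also leave open how this position would respond to a ring carrying an amine or a carboxylic acid, or to a plain phenyl ring with no added group.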